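Aryl substituent variation at the ring nitrogen: step to compound 4

The source may hold more compounds than are shown below. What is called first, only, known or untested is meant among the compounds shown, and "the series" means these compounds.

Measured compounds in an assay on isolated protein for inhibition of protein kinase C zeta type (Homo sapiens), with a stated time of 4 min, tested at 62.5 uM; a higher number here means more inhibition at the concentration tested (going by the name of the read-out), a lower number less inhibition:
compound 1, `CC(C)(C)C1=NN(c2ccc(F)cc2)C(c2ccc(O)cc2)C1`, gives 95.5%
compound 2, `CC(C)(C)C1=NN(c2cccc(Cl)c2)C(c2ccc(O)cc2)C1`, gives 96.8%
compound 3, `CC(C)(C)C1=NN(c2cccc(C(F)(F)F)c2)C(c2ccc(O)cc2)C1`, gives 96.1%

Compound 3 stands second highest of the three numbers; its nearest neighbour is compound 1, its furthest compound 2, and both of those gaps lie within the scatter, so the three compounds cannot be ordered. The two measured steps both change only the aryl group on the ring nitrogen of the shared core: a number 1.3 percentage points higher from compound 1 to compound 2 (within the scatter) and a number 0.7 percentage points lower from compound 2 to compound 3 (within the scatter), each within the scatter.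

Compound 4, `Cc1cccc(N2N=C(C(C)(C)C)CC2c2ccc(O)cc2)c1`, is not yet measured. It differs from compound 3 as follows: methyl in place of trifluoromethyl on an aromatic carbon. The change sits at the same place as the step from compound 2 to compound 3, where chloro became trifluoromethyl with no shift beyond the scatter, and the swap of the whole aryl group from compound 1 to compound 2 also left the number in place. On that basis no step beyond the scatter is expected for compound 4; the expected step is a number 0.6 percentage points lower from compound 3 to compound 4 (within the scatter).

Compound 4 is therefore estimated at 95.5% in this assay, with a range from 89% to 99.5%.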

Compound 4, a percentage reported as inhibition, at one concentration (the size of the read-out at that concentration, not a potency): 91.7%
Compound 4: the middle estimate sits 3.8 percentage points above what was measured; the measured number falls inside the stated range.
By their numbers in this assay, from the lowest: compounds 4, 1, 3 and 2 (each within the scatter of the next).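

In this assay, methyl at this aromatic carbon, a group with no fluorine or chlorine, leaves the read-out within the scatter of all three earlier compounds: a number 4.4 percentage points lower from compound 3 to compound 4 (within the scatter), a number 5.1 percentage points lower from compound 2 to compound 4 (within the scatter), and a number 3.8 percentage points lower from compound 1 to compound 4 (within the scatter). The earlier compounds shown here carried only fluoro, chloro or trifluoromethyl on the aryl group at the ring nitrogen, so compound 4 extends the flat picture to a substituent made of carbon and hydrogen alone, and the four compounds still cannot be ordered. Nothing measured here bears on why this position shows so little response to the change.

As far as these compounds go, whether an amine or a carboxylic acid at this aromatic carbon would also stay within the scatter remains open, as does the effect of changing the tert-butyl group or the hydroxy group of the shared core. this assay reports the size of the read-out at one concentration only, so whether compounds 1, 2, 3 and 4 would differ in a stronger or weaker effect at other concentrations also remains open.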